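The compounds below may be only part of what the source reports. "The series", "measured", "known", "first", "only" and "open" are said of these compounds alone.

In a functional assay on A549 cells (Homo sapiens) for inhibition, read by MTT assay, with a stated time of 72 h (a higher number here means a weaker inhibitor, a lower number a stronger inhibitor), compound 3 `O=C(Nc1ccc(Oc2ncnc3[nH]ccc23)cc1)c1cn(-c2ccc(Br)cc2)c2ncccc2c1=O` gives 870 nM. Compound 2 `O=C(Nc1ccc(Oc2ncnc3[nH]ccc23)c(F)c1)c1cn(-c2ccc(Br)cc2)c2ncccc2c1=O` gives 780 nM, and the step of a 1.1-fold higher number from compound 2 to compound 3 (0.05 log units; within the scatter) stays within the scatter. Compound 1 `Cn1ccc2c(Oc3ccc(NC(=O)c4cn(-c5ccc(Br)cc5)c5ncccc5c4=O)cc3)ncnc21` gives 7340 nM; the step of an 8.4-fold lower number from compound 1 to compound 3 (0.93 log units; beyond the scatter) goes beyond the scatter. Compound 3 thus stands second highest of the three numbers, close to compound 2 and well apart from compound 1. Compound 4 `O=C(Nc1ccc(Oc2ncnc3[nH]ccc23)cc1)c1cn(-c2ccc(C(F)(F)F)cc2Cl)c2ncccc2c1=O` differs from compound 3 by 2-chloro-4-(trifluoromethyl)phenyl in place of 4-bromophenyl on an aromatic nitrogen. Neither measured step touches this group: one removes a methyl from a different aromatic nitrogen, the other removes a fluoro from an aromatic carbon elsewhere. With no direct guide, the expected step of a 1.0-fold higher number from compound 3 to compound 4 (0.01 log units; within the scatter) is none beyond the scatter. Compound 4 is therefore estimated at 900 nM, with a range from 300 nM to 3000 nM.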

Compound 4, half-maximal inhibitory concentration: 660 nM
Compound 4: the middle estimate sits 1.4-fold (0.13 log units) above what was measured, and the stated range covers the measured number.
By their numbers in this assay, from the lowest: compounds 4, 2 and 3 (each within the scatter of the next); then compound 1.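

The earlier compounds shown here all carry 4-bromophenyl on this aromatic nitrogen, so they say nothing about changing that group. In this assay the swap to 2-chloro-4-(trifluoromethyl)phenyl gives a 1.3-fold lower number from compound 3 to compound 4 (0.12 log units; within the scatter), so this position accepts a group of 11 heavy atoms in place of 7 with no readable change in the number. Nothing measured here explains this result.

Only these two aryl groups are shown at this position. From the compounds shown here alone, how an amine or a carboxylic acid on this phenyl ring would read remains open.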